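A few compounds are considered here, and "the series" means these few. Any claim that something is new, unique, unknown or untested is made for them only; others in the source may bear on it.

In an ADME assay on C8166 cells (Homo sapiens) for cytotoxicity, read by MTT assay (a lower number here means that less compound is tolerated, a higher number that more compound is tolerated), compound 1 `O=C(O)c1cn(-c2ccccc2)c2ccc(Cc3cccc(Cl)c3F)c(O)c2c1=O` gives 388000 nM and compound 2 `O=C(O)c1cn(Cc2ccccc2F)c2ccc(Cc3cccc(Cl)c3F)c(O)c2c1=O` gives 44900 nM, so compound 2 holds the lower of the two numbers. Compound 3 `O=C(O)c1cn(Cc2cccc(F)c2)c2ccc(Cc3cccc(Cl)c3F)c(O)c2c1=O` differs from compound 2 by 3-fluorophenyl in place of 2-fluorophenyl on a saturated chain carbon bound to an aromatic nitrogen. In words, 3-fluorophenyl stands in place of 2-fluorophenyl on a saturated chain carbon bound to an aromatic nitrogen. Among the compounds with values here, the only measured step is an 8.6-fold lower number from compound 1 to compound 2 (0.94 log units; beyond the scatter), with 2-fluorobenzyl in place of phenyl on an aromatic nitrogen. That step bears only loosely on this change, as it exchanged a different pair of groups. Within the data shown here, no measured step covers 2-fluorobenzyl to 3-fluorobenzyl, so the range is kept wide. No step beyond the scatter is expected in this assay, in either direction, and the expected step is a 1.1-fold higher number from compound 2 to compound 3 (0.05 log units; within the scatter). Compound 3 is estimated at 50000 nM, with an expected range of 20000 nM to 125000 nM.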

Compound 3, half-maximal cytotoxic concentration: 69000 nM
The estimate for compound 3 lay 1.4-fold (0.14 log units) below the measured number; the range from low to high includes it.
By their numbers in this assay, from the lowest: compounds 2 and 3 (each within the scatter of the next); then compound 1.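

In this assay, 3-fluorobenzyl in place of 2-fluorobenzyl on an aromatic nitrogen gives a 1.5-fold higher number from compound 2 to compound 3 (0.19 log units; within the scatter), so the two fluorobenzyl compounds cannot be told apart at this position. The step of a 5.6-fold lower number from compound 1 to compound 3 (0.75 log units; beyond the scatter) is beyond the scatter and runs in the same direction as an 8.6-fold lower number from compound 1 to compound 2 (0.94 log units; beyond the scatter), so the shift away from the phenyl of compound 1 now holds for both fluorobenzyl groups rather than for one alone. Nothing measured here offers an explanation for these numbers.

The compounds shown leave open whether plain benzyl, without fluorine, would stand with compound 2 and compound 3 or nearer to compound 1. As far as these compounds go, it also remains open how a longer chain such as phenethyl, or an amine on the chain, would read in this assay.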